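Oxime to ketone on the thioether chain

This account rests on a few compounds, and the source may have more. Where it says the series, first, only, none or still open, it means among the compounds named here.

Among the compounds with values here, compound 2 `O/N=C(/CSc1nnc(-c2ccccc2)n1-c1ccccc1)c1ccccc1` stands highest of the two values so far. In a functional assay on the whole organism (strain albino) for inhibition, with Rattus norvegicus as the target, read by paw edema, with a stated time of 4 h, at a dose of 0.28 mmol/kg by the oral route (a higher number here means more inhibition at the dose given (going by the name of the read-out), a lower number less inhibition), compound 2 gives 79%. Compound 1 `C=CCn1c(SCC(=O)c2ccccc2)nnc1-c1ccccc1`, the nearest point, sits a gap beyond the scatter lower, and in this assay compound 1 gives 66%. Compound 3 `O=C(CSc1nnc(-c2ccccc2)n1-c1ccccc1)c1ccccc1` differs from compound 2 by a group of 8 heavy atoms (7 carbon, 1 oxygen; one six-membered aromatic ring of carbon only) in place of a group of 9 heavy atoms (7 carbon, 1 nitrogen, 1 oxygen; one six-membered aromatic ring of carbon only), on a saturated chain carbon bound to a sulfur. Within the data shown here, no step for this change has been measured. A modest drop is expected in this assay, amounting to a number 11 percentage points lower from compound 2 to compound 3 (beyond the scatter). Compound 3 is therefore estimated at 68%, with a range from 55% to 80%.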

Compound 3, a percentage reported as inhibition, in the whole organism at one dose (the size of the read-out at that dose, not a potency): 68%
Compound 3: middle estimate and measured number agree at the digits printed; low and high end bracket the measured number.
By their numbers in this assay, from the lowest: compounds 1 and 3 (each within the scatter of the next); then compound 2.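

Benzoyl in place of the oxime-bearing group, on a saturated chain carbon bound to a sulfur, gives a number 11 percentage points lower from compound 2 to compound 3 (beyond the scatter) in this assay, so this position responds to the change. With the ketone chain held constant, phenyl in place of allyl on an aromatic nitrogen gives a number 2 percentage points higher from compound 1 to compound 3 (within the scatter), so that swap does not separate the two compounds. Nothing at hand bears on the origin of the step at the chain.

Going by these compounds, whether the oxime step carries over with allyl on the aromatic nitrogen remains open. So does the outcome with an amine or a carboxylic acid at the chain position, or with a longer chain between the sulfur and the benzoyl.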